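Swapping the aryl group on a thiosemicarbazone: an expectation

The compounds below may be only part of what the source reports. "The series", "measured", "known", "first", "only" and "open" are said of these compounds alone.

Measured compounds:
compound 1, `COc1ccccc1NC(=S)N/N=C/c1ccc2ccccc2n1`: 91700 nM
compound 2, `CN(C)C(=S)N/N=C/c1nc2ccccc2s1`: 3680 nM

In a functional assay on HL-60 cells (Homo sapiens) for antiproliferative activity, read by sulforhodamine B assay, with a stated time of 72 h (a higher number here means a weaker inhibitor, a lower number a stronger inhibitor), compound 1 gives 91700 nM, the higher of the two numbers recorded. Compound 2, built on a different core, gives 3680 nM, a gap beyond the usual scatter. Compound 3, `S=C(N/N=C/c1ccc2ccccc2n1)Nc1cccc(Cl)c1`, has not been measured; it differs from compound 1 in one place: 3-chlorophenyl in place of 2-methoxyphenyl on an amide-type nitrogen. Going by the values given here, no measured pair shows what such a swap does here, so the step is expected to be small, with a slight lean toward a lower number. Compound 3 is therefore estimated at 50000 nM, within 15000 nM to 150000 nM, a change of a 1.8-fold lower number from compound 1 to compound 3 (0.26 log units; within the scatter) expected from compound 1.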

Compound 3, half-maximal inhibitory concentration: 28800 nM
Estimate against measurement, compound 3: 1.7-fold (0.24 log units) above, and the stated range covers the measured number.
By their numbers in this assay, from the lowest: compound 2; then compound 3; then compound 1.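

In this assay, going by these compounds alone, this swap gives the first readable step at the amide-type nitrogen: with 3-chlorophenyl in place of 2-methoxyphenyl, there is a 3.2-fold lower number from compound 1 to compound 3 (0.50 log units; beyond the scatter). The aryl group at this position therefore affects the antiproliferative reading, though only modestly. No measurement here accounts for the step.

From the compounds shown here alone, it remains open whether the change comes from removing the 2-methoxyphenyl or from adding the 3-chlorophenyl, since the two were exchanged together. Also open, going by these compounds, is what an amine, a carboxylic acid or a longer chain would do on this nitrogen.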